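Acyclic amide in place of the azole on the chain carbon

The source may hold more compounds than are shown below. What is called first, only, known or untested is meant among the compounds shown, and "the series" means these compounds.

Compound 3, `CC(C)C(c1noc(=O)[nH]1)c1ccc(-c2ccc3cccc(F)c3c2)[nH]c1=O`, is measured in an assay on CHO cells for displacement of a labelled ligand from prostaglandin E2 receptor EP3 subtype (Homo sapiens), read by radioligand binding (on this read-out lower numbers stand for stronger inhibition and higher numbers for weaker inhibition), at 15 nM. Compound 1, `CC(C)C(Cc1ncc[nH]1)c1ccc(-c2ccc3cccc(F)c3c2)[nH]c1=O`, gives 11 nM and compound 2, `CC(C)C(Cc1nnc[nH]1)c1ccc(-c2ccc3cccc(F)c3c2)[nH]c1=O`, gives 10 nM. The three values sit together: a 1.1-fold lower number from compound 1 to compound 2 (0.04 log units; within the scatter), a 1.4-fold higher number from compound 1 to compound 3 (0.13 log units; within the scatter) and a 1.5-fold higher number from compound 2 to compound 3 (0.18 log units; within the scatter) all fall within the scatter, so swapping one five-membered azole for another on the chain carbon has not moved the read-out here.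

Compound 4, `CC(C)NC(=O)CC(c1ccc(-c2ccc3cccc(F)c3c2)[nH]c1=O)C(C)C`, differs from compound 3 by a group of 7 heavy atoms (5 carbon, 1 nitrogen, 1 oxygen; no ring) in place of a group of 6 heavy atoms (2 carbon, 2 nitrogen, 2 oxygen; one five-membered aromatic ring with 3 hetero atoms), on a saturated chain carbon bound to an aromatic carbon and a saturated chain carbon. Going by the values given here, no measured step covers a change of this kind: every step so far exchanges one five-membered ring for another, whereas here the ring is lost and an open chain with an amide enters. The measured steps therefore set no more than a loose bound; they show that the read-out has tolerated variation at this carbon, but only among ring groups. A modest weakening is expected, with wide uncertainty. For compound 4 the expected value in this assay is 40 nM, with a range from 10 nM to 160 nM. The step this estimate implies, a 2.7-fold higher number from compound 3 to compound 4 (0.43 log units; beyond the scatter), is an expectation and not a measurement.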

Compound 4, inhibition constant: 5.8 nM
For compound 4 the middle estimate is 6.9-fold (0.84 log units) above the measured one; measured number below the stated range.
By their numbers in this assay, from the lowest: compounds 4, 2, 1 and 3 (each within the scatter of the next, the first and the last beyond it).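

In this assay, the ring on the saturated chain carbon proves dispensable among these compounds: the open (isopropylcarbamoyl)methyl group not only holds the read-out but gives the first step in the series beyond the scatter (a 2.6-fold lower number from compound 3 to compound 4 (0.41 log units; beyond the scatter)). That step replaces the ring and also changes the link to the chain carbon, whereas the two steps that keep the group two bonds along the chain from an aromatic carbon, with isopropylcarbamoyl replacing a ring, stay within the scatter (a 1.7-fold lower number from compound 2 to compound 4 (0.24 log units; within the scatter) and a 1.9-fold lower number from compound 1 to compound 4 (0.28 log units; within the scatter)), so at this place the acyclic amide stands level with the 4H-1,2,4-triazol-3-yl and 1H-imidazol-2-yl groups. No measurement available here speaks to what lies behind the step from the oxadiazolone-bearing compound 3 to the amide.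

Still open, going by these compounds, is whether the amide hydrogen matters, which an N,N-dimethyl amide would test, and whether a carboxylic acid or a primary amine on the same chain would be accepted. Also open, on these data alone, is how far the isopropyl group on the amide nitrogen can change, for instance to a cyclopropyl or a longer chain such as n-butyl.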